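The source may hold more compounds than are shown below. What is called first, only, known or untested is meant among the compounds shown, and "the series" means these compounds.

Measured compounds in an assay on cells for inhibition of HSP60/HSP10 (Homo sapiens), with a stated time of 60 min; a higher number here means a weaker inhibitor, a lower number a stronger inhibitor:
- compound 1 `O=S(=O)(Nc1ccc(-c2nc3ccccc3o2)cc1)c1cccc(F)c1` gives 71000 nM
- compound 3 `O=S(=O)(Nc1ccc(-c2nc3ccccc3o2)cc1)c1ccc(O)cc1` gives 78000 nM
- compound 2 `Cc1ccc(S(=O)(=O)Nc2ccc3oc(-c4ccccc4)nc3c2)cc1` gives only a limit of the assay, > 100000 nM

Compound 2 therefore stands at the upper edge of what the assay reports; the numbers for compound 1 and compound 3 lie below that edge, and no distance between compound 2 and either of them can be stated (the limit of > 100000 nM in this assay, at which 1 of the 3 values shown sits).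

The unmeasured compound 4 `CS(=O)(=O)Nc1ccc2oc(-c3ccccc3)nc2c1` differs from compound 2 in one place (methyl in place of 4-methylphenyl on a sulfonyl sulfur).

Among the measured compounds shown here, the only measured step is a 1.1-fold higher number from compound 1 to compound 3 (0.04 log units; within the scatter), which exchanges one aryl group for another on the sulfonyl sulfur and sits within the scatter. For the measured compounds named here, it shows that one aryl-to-aryl swap at that position leaves this assay unchanged, but no measured step removes the aryl group altogether, as happens here, and compound 2 itself has only a limit. The bearing on the present step is weak.

On what is shown, no step beyond the scatter is expected from compound 2 to compound 4, and compound 4 is expected to remain near the limit: 100000 nM, range 30000 nM to 300000 nM, meaning an expected step of a number no higher from compound 2 to compound 4 (the limit leaves the size open).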

Compound 4, half-maximal inhibitory concentration: > 100000 nM
Compound 4: only a limit was reported (the forecaster's own chance of this, stated with the estimate: 60%); the middle value lies on the limit itself.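

In this assay, among the compounds shown here, compound 2 and compound 4 both stand only at a limit of the assay, so no step between them can be read. The compounds shown leave open how far methyl in place of 4-methylphenyl on a sulfonyl sulfur moves the number, and where the true number of either compound lies.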